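Aminomethyl to 1-aminoethyl: compound 4 from compound 1

The source may report more compounds than this note shows. Statements on the series, on what has been measured and on what is new or still open speak of the compounds shown alone.

Measured so far, in an assay on HEK293 cells for displacement of a labelled ligand from Melanocortin receptor 4 (Homo sapiens); a higher number here means a weaker inhibitor, a lower number a stronger inhibitor:
- compound 1 `Cc1ccc(N2CCN(C(=O)[C@@H]3CN(C4CCOCC4)C[C@H]3c3ccc(Cl)cc3)CC2)c([C@@H](NC(=O)CN)C(C)C)c1`: 2 nM
- compound 2 `CC(C)[C@H](NC(=O)CCN(C)C)c1cccc(F)c1N1CCN(C(=O)[C@@H]2CN(C(C)C)C[C@H]2c2cccc(F)c2)CC1`: 560 nM
- compound 3 `CC(C)[C@H](NC(=O)CCN(C)C)c1cccc(F)c1N1CCN(C(=O)[C@@H]2CN(C(C)C)C[C@H]2c2ccc(C(F)(F)F)cc2F)CC1`: 61 nM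

Compound 1 gives the lowest number of the three in this assay; compound 3 and compound 2 both sit beyond the scatter above it. For the measured compounds named here, the only measured single-point step, a 9.2-fold lower number from compound 2 to compound 3 (0.96 log units; beyond the scatter), concerns the aryl group on the saturated ring, a part of the molecule left untouched here, so it does not bear on the present change.

Compound 4 `Cc1ccc(N2CCN(C(=O)[C@@H]3CN(C4CCOCC4)C[C@H]3c3ccc(Cl)cc3)CC2)c([C@@H](NC(=O)[C@@H](C)N)C(C)C)c1` differs from compound 1 by methyl in place of hydrogen on a saturated chain carbon bound to an amine nitrogen and a carbonyl carbon. Going by the values given here, no measured pair covers this change. A small step is expected in this assay, a 1.3-fold higher number from compound 1 to compound 4 (0.10 log units; within the scatter), likely within the scatter. Compound 4 is estimated at 2.5 nM, range 0.8 nM to 8 nM.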

Compound 4, inhibition constant: 7.3 nM
For compound 4 the middle estimate is 2.9-fold (0.47 log units) below the measured one; the range from low to high includes it.
By their numbers in this assay, from the lowest: compound 1; then compound 4; then compound 3; then compound 2.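

In this assay, methyl in place of hydrogen on a saturated chain carbon bound to an amine nitrogen and a carbonyl carbon gives a 3.7-fold higher number from compound 1 to compound 4 (0.56 log units; beyond the scatter), a modest step. For the compounds shown here, this is the first measured step at this position, and it shows that the number responds to the addition of one methyl there. Nothing measured here accounts for the step.

Going by these compounds, whether an ethyl or hydroxymethyl group in place of this methyl would raise the number further remains open. On these data alone, the effect of reversing the configuration at the 1-aminoethyl carbon also remains open.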